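Butoxy to Chloro on the Aryl Ring: Cytotoxicity Outlook

The source may hold more compounds than are shown below. What is called first, only, known or untested is meant among the compounds shown, and "the series" means these compounds.

Compound 1, `C=Cc1cccc(-c2[nH]c3cc(OC)ccc3c(=O)c2C(=O)OCC)c1`: in an ADME assay on BJ cells (Homo sapiens) for cytotoxicity, read by luminescence, with a stated time of 72 h (on this read-out lower numbers stand for an effect already at smaller amounts and higher numbers for an effect only at larger amounts of compound), compound 1 gives > 21500 nM, a limit of the assay.
Compound 2, `CCCCOc1cccc(-c2[nH]c3cc(OC)ccc3c(=O)c2C(=O)OCC)c1`: in this assay compound 2 gives > 21500 nM, also a limit of the assay.

Compound 2 thus sits at the limit of > 21500 nM in this assay, at which 2 of the 2 values shown sit. The step that the two limits leave unreadable from compound 1 to compound 2 cannot be read. Compound 3, `CCOC(=O)c1c(-c2cccc(Cl)c2)[nH]c2cc(OC)ccc2c1=O`, differs from compound 2 by chloro in place of butoxy on an aromatic carbon. Among the compounds with values here, the only measured step concerns a change at the same aromatic carbon, yet its size is unreadable, so no step beyond the scatter is expected in this assay in either direction. Compound 3 is therefore estimated at 21500 nM, between 9000 nM and 50000 nM, most likely again as a limit. The expected step of a number no higher from compound 2 to compound 3 (the limit leaves the size open) is none beyond the scatter.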

Compound 3, half-maximal effective concentration: > 21500 nM
Compound 3: no number, only a limit (the forecaster's own chance of this, stated with the estimate: 85%); the middle value lies on the limit itself.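

No step can be read from compound 1 or compound 2 to compound 3; all three values are limits of the assay. The compounds shown leave open whether vinyl, butoxy and chloro differ at all in this assay.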